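Two Inverted Ring Stereocentres and Expected Clearance

The source may report more compounds than this note shows. Statements on the series, on what has been measured and on what is new or still open speak of the compounds shown alone.

Within the data shown here, compound 1 `COC(=O)N[C@H](C(=O)N1CCC[C@H]1C(=O)Nc1ccc([C@@H]2CC[C@@H](c3ccc(NC(=O)[C@@H]4CCCN4C(=O)[C@@H](NC(=O)OC)[C@H]4CCOC4)cc3)N2c2ccc(F)cc2)cc1)[C@H]1CCOC1` is the only compound with a numerical result in an ADME assay on the whole organism for pharmacokinetics, with Rattus norvegicus as the target, at a dose of 3 mg/kg by the intravenous route; a lower number here means slower removal, a higher number faster removal of the compound: compound 1 gives 31.7 mL/min/kg. The one other result is a limit of the assay rather than a number. Compound 2 `COC(=O)N[C@H](C(=O)N1CCC[C@H]1C(=O)Nc1ccc([C@@H]2CC[C@@H](c3ccc(NC(=O)[C@@H]4CCCN4C(=O)[C@@H](NC(=O)OC)C(C)(C)C)cc3)N2c2ccc(F)cc2)cc1)C(C)(C)C` gives < 6.5 mL/min/kg in this assay. For compound 2 this is the limit of < 6.5 mL/min/kg in this assay, at which 1 of the 2 values shown sits. Among the measured compounds shown here, with one number and one limit, no step between measured compounds can be sized. Compound 3 `COC(=O)N[C@H](C(=O)N1CCC[C@H]1C(=O)Nc1ccc([C@H]2CC[C@H](c3ccc(NC(=O)[C@@H]4CCCN4C(=O)[C@@H](NC(=O)OC)[C@H]4CCOC4)cc3)N2c2ccc(F)cc2)cc1)[C@H]1CCOC1` has not yet been measured in this assay. Compound 3 differs from compound 1 only in configuration: the two compounds have the same atoms and bonds and differ only in configuration as drawn: 2 of 8 stereo elements differ; a stereocentre at a saturated ring carbon is drawn S in compound 1 and R in compound 3; a stereocentre at a saturated ring carbon is drawn S in compound 1 and R in compound 3, the two stereocentres at saturated ring carbons being drawn S in compound 1 and R in compound 3. Nothing measured shows what inverting these centres does to clearance; a shift in either direction that stays within the usual scatter is expected. Compound 3 is therefore estimated at 30 mL/min/kg in this assay, between 12 mL/min/kg and 60 mL/min/kg. The expected step is a 1.1-fold lower number from compound 1 to compound 3 (0.02 log units; within the scatter).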

Compound 3, clearance in the Rattus norvegicus assay: 66.7 mL/min/kg
Compound 3: middle estimate off by 2.2-fold (0.35 log units), on the low side, outside the stated range (above it).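

Among these compounds, this pair gives the first measured step in the study, and it concerns the two stereocentres at saturated ring carbons: in the Rattus norvegicus assay compound 1 gives 31.7 mL/min/kg and compound 3 gives 66.7 mL/min/kg. In the Rattus norvegicus assay, inverting both centres gives a 2.1-fold higher number from compound 1 to compound 3 (0.32 log units; beyond the scatter), a modest step, and it can be tied to configuration alone: the fact that compounds 1 and 3 differ only in the configuration as drawn In a physicochemical assay for lipophilicity, read by HPLC, at pH 7.4 (on this read-out higher numbers stand for higher lipophilicity and lower numbers for lower lipophilicity), compound 1 gives 3.2 and compound 3 gives 3.2. In the physicochemical assay the same pair shows no change at the digits printed from compound 1 to compound 3 (within the scatter), so the clearance step comes with no measurable difference in this read-out.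

The compounds shown do not tell whether one of the two centres accounts for the step, as both are inverted together, or what lies behind the higher clearance of compound 3. From the compounds shown here alone, it also remains open whether an amine or a carboxylic acid in place of the fluorine on the shared core would preserve this difference between the two configurations.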